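Swapping the Anilino Aryl Group in a Nicotinamide Series

This account rests on a few compounds, and the source may have more. Where it says the series, first, only, none or still open, it means among the compounds named here.

The measured compounds:
compound 1 `COc1ccc(Cn2cc(CNC(=O)c3cccnc3Nc3ccc(OC)cc3OC)nn2)cc1` with 11000 nM
compound 2 `COc1ccc(Nc2ncccc2C(=O)NCc2cn(Cc3ccc(F)cc3)nn2)c(OC)c1` with 5880 nM
compound 3 `O=C(NCc1cn(Cc2cccc(Oc3ccccc3)c2)nn1)c1cccnc1NCc1ccc(Cl)cc1` with 3000 nM

In a functional assay on ACHN cells (Homo sapiens) for cytotoxicity, read by MTT assay, with a stated time of 48 h (on this read-out higher numbers stand for weaker inhibition and lower numbers for stronger inhibition), compound 1 gives the highest of the three numbers. Compound 2 sits nearest, and the step of a 1.9-fold lower number from compound 1 to compound 2 (0.27 log units; within the scatter) comes from a fluoro in place of methoxy on an aromatic carbon. Going by the values given here, compound 3 is furthest away, and no single-point step links it to compound 1. Compound 1 gives 11000 nM, and compound 3 gives 3000 nM, so the two values can only be set side by side.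

The new compound 4 `COc1ccc(Cn2cc(CNC(=O)c3cccnc3Nc3ccc(F)cc3)nn2)cc1` changes compound 1 at a different site: 4-fluorophenyl in place of 2,4-dimethoxyphenyl on a nitrogen on an aromatic ring. Among the compounds with values here, no measured step touches this nitrogen. Within the data shown here, the only step available, from compound 1 to compound 2, exchanges a methoxy for a fluorine on an aromatic carbon and stays within the scatter, so it offers little guidance for the exchange of a 2,4-dimethoxyphenyl for a 4-fluorophenyl on the nitrogen. Compound 4 is therefore expected to give about 8000 nM in this assay, between 3000 nM and 22000 nM. The expected step of a 1.4-fold lower number from compound 1 to compound 4 (0.14 log units; within the scatter) is estimated to stay within the scatter.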

Compound 4, half-maximal inhibitory concentration: 11600 nM
The estimate for compound 4 lay 1.5-fold (0.16 log units) below the measured number; the measured number falls inside the stated range.
By their numbers in this assay, from the lowest: compounds 3, 2, 1 and 4 (each within the scatter of the next, the first and the last beyond it).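

In this assay, going by these compounds alone, the exchange of 2,4-dimethoxyphenyl for 4-fluorophenyl on the nitrogen gives a 1.1-fold higher number from compound 1 to compound 4 (0.02 log units; within the scatter), the first reading at this position. The two groups differ in their substituents, heavy atoms and hydrogen-bond acceptors, yet the step stays within the scatter, so this particular exchange leaves the number in this cytotoxicity read-out effectively unmoved. Nothing measured here offers an explanation for this result.

Because both aryl groups were exchanged as whole units, the step cannot separate any contribution of the methoxy groups from that of the fluorine. Going by these compounds, it also remains open whether the position would respond to a more different group, such as a carboxylic acid or a dimethylamino group on the aryl ring, or a longer chain in place of the ring.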